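Working notes: one substituent change on the shared core

A few compounds are considered here, and "the series" means these few. Any claim that something is new, unique, unknown or untested is made for them only; others in the source may bear on it.

Measured compounds:
compound 1 `CC[C@@H]1C(=O)N(C)c2cnc(-n3ccc4cc(F)ccc43)nc2N1C1CCCC1` — 969 nM
compound 2 `CCC1C(=O)N(C)c2cnc(Nc3ccc(S(=O)(=O)NCCO)cc3)nc2N1c1ccn(C)n1` — 478 nM
compound 3 `CCC1C(=O)N(C)c2cnc(-n3ccc4cc(C(=O)NC(C)C)ccc43)nc2N1c1ccn(C)n1` — 125 nM

All three numbers come from an assay for inhibition of serine/threonine-protein kinase PLK2 (Homo sapiens), read by FRET and Z'-LYTE, with a stated time of 1 h; a lower number here means a stronger inhibitor, a higher number a weaker inhibitor. Compound 1 stands highest of the three. Its nearest neighbour is compound 2, whose number is lower by a margin beyond the usual scatter; the furthest is compound 3, lower again by a clearly larger margin. Compound 2 and compound 3 each differ from compound 1 in more than one place, so no single-change step can be drawn from the measured set, and nothing is said here about why either number is lower.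

Compound 4 `CC[C@@H]1C(=O)N(C)c2cnc(-n3ccc4cc(C(N)=O)ccc43)nc2N1C1CCCC1` is the next compound for this assay. It differs from compound 1 in one place only: carbamoyl in place of fluoro on an aromatic carbon. The rest of the shared core, including the ethyl group and the cyclopentyl substituent, is unchanged.

Going by the values given here, with no one-change step among the measured compounds to lean on, the expectation rests on the standing of compound 1 alone: as the highest of the three numbers, it leaves room downward. A moderate step downward, beyond the scatter, is expected from compound 1 to compound 4, a 3.0-fold lower number from compound 1 to compound 4 (0.48 log units; beyond the scatter). For compound 4 the estimated value in this assay is 320 nM, with a range from 110 nM to 950 nM.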

Compound 4, half-maximal inhibitory concentration: 28.5 nM
Compound 4: middle estimate off by 11-fold (1.05 log units), on the high side; the measured number lies below the stated range.
By their numbers in this assay, from the lowest: compound 4; then compound 3; then compound 2; then compound 1.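

Going by these compounds alone, at the aromatic carbon para to a fused ring and meta to a fused ring, on the six-membered aromatic ring of carbon only, carbamoyl in place of fluoro gives in this assay a 34-fold lower number from compound 1 to compound 4 (1.53 log units; beyond the scatter) as the first single-change step, and a large one. Within the data shown here, every pair among the earlier compounds differs in more than one place, so only this step shows that the number responds strongly to the substituent at this position while the ethyl group and the cyclopentyl substituent stay fixed. No measurement is at hand to say which feature of the carbamoyl group carries the step, whether its added heavy atoms, its hydrogen-bond donor or its hydrogen-bond acceptor.

Still open, from the compounds shown here alone, is how a nitrile, a carboxylic acid or a methylamide at the same aromatic carbon would compare with carbamoyl. Also open, going by these compounds, is whether the step would hold with a longer chain in place of the ethyl group or with an amine in place of the cyclopentyl substituent.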